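Chloro on the Phenyl Ring: Expectation for Compound 4

The compounds below may be only part of what the source reports. "The series", "measured", "known", "first", "only" and "open" are said of these compounds alone.

Compound 1 `COc1ccc(OC)c(-c2cc(-c3ccccc3)nn2-c2ccc(S(=O)(=O)NC(C)=O)cc2)c1` gives 13300 nM in a functional assay on cells (Cancer cell lines, Homo sapiens) for cytotoxicity, read by sulforhodamine B assay, with a stated time of 48 h; on this read-out higher numbers stand for weaker inhibition of growth and lower numbers for stronger inhibition of growth.
Compound 2 `COc1ccc(OC)c(-c2cc(-c3ccc(Cl)cc3)nn2-c2ccc(S(=O)(=O)NC(C)=O)cc2)c1` gives 17700 nM in this assay.
Compound 3 `CC(=O)NS(=O)(=O)c1ccc(-n2nc(-c3ccccc3)cc2-c2cc(O)ccc2O)cc1` gives 78100 nM in this assay.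

The change from compound 1 to compound 2 is chloro in place of hydrogen on an aromatic carbon. Its effect was a 1.3-fold higher number from compound 1 to compound 2 (0.12 log units; within the scatter), so the chloro made no clear difference there. Compound 3 differs from compound 1 in its core by 2,5-dihydroxyphenyl in place of 2,5-dimethoxyphenyl on an aromatic carbon, and that switch gave a 5.9-fold higher number from compound 1 to compound 3 (0.77 log units; beyond the scatter). Compound 4 `CC(=O)NS(=O)(=O)c1ccc(-n2nc(-c3ccc(Cl)cc3)cc2-c2cc(O)ccc2O)cc1` is not yet measured; it arises from compound 3 by chloro in place of hydrogen on an aromatic carbon, the same change as from compound 1 to compound 2, at the same kind of place. Among the measured compounds shown here, with only one earlier example, the expected step in this assay is small, a 1.2-fold higher number from compound 3 to compound 4 (0.09 log units; within the scatter), because compound 1 to compound 2 showed a 1.3-fold higher number from compound 1 to compound 2 (0.12 log units; within the scatter). Compound 4 is therefore estimated at 95000 nM, with a likely range from 40000 nM to 250000 nM.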

Compound 4, concentration for 50% growth inhibition: 23500 nM
Beside the measured number, compound 4's estimate is 4.0-fold (0.61 log units) above it, outside the stated range (below it).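

Chloro in place of hydrogen did not carry over unchanged from one core to the other, as the step on the dihydroxyphenyl core, a 3.3-fold lower number from compound 3 to compound 4 (0.52 log units; beyond the scatter), does not match the earlier one: the same change on two cores in this assay, a 1.3-fold higher number (0.12 log units; within the scatter) from compound 1 to compound 2 and a 3.3-fold lower number (0.52 log units; beyond the scatter) from compound 3 to compound 4, 4.4-fold (0.65 log units) apart, beyond the scatter of two such steps. The switch to 2,5-dihydroxyphenyl likewise depends on what else is present, since with chloro on the phenyl ring it gives a 1.3-fold higher number from compound 2 to compound 4 (0.12 log units; within the scatter), and the two cases disagree: the same change on two cores in this assay, a 5.9-fold higher number (0.77 log units; beyond the scatter) from compound 1 to compound 3 and a 1.3-fold higher number (0.12 log units; within the scatter) from compound 2 to compound 4, 4.4-fold (0.65 log units) apart, beyond the scatter of two such steps. So the two changes do not simply add up in this assay, but one pair of steps cannot show why, or whether this holds beyond these compounds.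

The compounds shown leave open whether another group in the same place, such as fluoro, methyl or methoxy, would also act differently on the two cores.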